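The source may hold more compounds than are shown below. What is called first, only, known or untested is meant among the compounds shown, and "the series" means these compounds.

Measured in an ADME assay on J774 cells (Mus musculus) for cytotoxicity, read by MTT assay, with a stated time of 48 h; on this read-out higher numbers stand for weaker inhibition and lower numbers for stronger inhibition:
Compound 1 `CC(C)(C)OC(=O)NCCNc1cc(/C=C/c2ccccc2)nc2ccccc12`: 6600 nM
Compound 2 `NCCNc1cc(/C=C/c2ccccc2)nc2ccccc12`: 4600 nM
Compound 3 `O=C(CNc1ccccc1)NCCNc1cc(/C=C/c2ccccc2)nc2ccccc12`: 7800 nM

Seen from compound 2, neither measured step leaves the usual scatter: the first is a 1.4-fold lower number from compound 1 to compound 2 (0.16 log units; within the scatter), and the second is a 1.7-fold higher number from compound 2 to compound 3 (0.23 log units; within the scatter). On these numbers, compound 2 cannot be separated from the other two.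

The unmeasured compound 4 `Nc1cc(/C=C/c2ccccc2)nc2ccccc12` differs from compound 2 in one place: hydrogen in place of 2-aminoethyl on a nitrogen on an aromatic ring. Hydrogen stands in place of 2-aminoethyl on a nitrogen on an aromatic ring, so the whole chain is gone.

The measured steps bear on this only indirectly. Each changes what sits on the amine nitrogen of that chain, and none removes the chain itself. The remaining step, a 1.2-fold higher number from compound 1 to compound 3 (0.07 log units; within the scatter), is small as well, so these data offer no reason to expect a large shift, although they do not test this change directly.

The estimated step is a 1.3-fold higher number from compound 2 to compound 4 (0.12 log units; within the scatter), which means no clear change is expected in this assay.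

For compound 4 the estimated value is 6000 nM, with an expected range of 2500 nM to 15000 nM.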

Compound 4, half-maximal inhibitory concentration: 4400 nM
The estimate for compound 4 lay 1.4-fold (0.13 log units) above the measured number; measured number inside the range.
By their numbers in this assay, from the lowest: compounds 4, 2, 1 and 3 (each within the scatter of the next).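

In this assay, taking the whole 2-aminoethyl group off the nitrogen on the aromatic ring gives a 1.0-fold lower number from compound 2 to compound 4 (0.02 log units; within the scatter) and leaves a plain amino group. The earlier compounds shown here changed only what sat on the amine nitrogen of that chain, whereas this step removes the chain itself, and even so compound 4 cannot be told apart from compound 2. Among these compounds, then, the chain is not required for the cytotoxicity seen on these cells, and no supporting measurement is available to explain this result.

On these data alone, a longer chain such as 3-aminopropyl on the same nitrogen remains open, as does a carboxylic acid in place of the chain's amine. Whether either group would separate from compound 2 in this assay is also unresolved.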